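Nitrofuran thiazole amides: Vero cytotoxicity, bromo to cyclohexylamide

The source may hold more compounds than are shown below. What is called first, only, known or untested is meant among the compounds shown, and "the series" means these compounds.

Working notes on the nitrofuran carboxamide series measured in an ADME assay on Vero cells (Chlorocebus sabaeus) for cytotoxicity, read by MTT assay, with a stated time of 72 h; on this read-out higher numbers stand for weaker inhibition and lower numbers for stronger inhibition. Compound 1 `O=C(Nc1nc(-c2cccc(Br)c2)cs1)c1ccc([N+](=O)[O-])o1` gives 71000 nM in this assay. Compound 2 `Cc1cc(C)c(-c2csc(NC(=O)c3ccc([N+](=O)[O-])o3)n2)c(C)c1` gives 30400 nM in this assay. Compound 3 `COc1cccc(-c2csc(NC(=O)c3ccc(N)o3)n2)c1` is recorded in this assay as "not determined" (no result reported), so no number is in hand for it. Among the two numbers in hand, compound 1 stands highest; compound 2 sits at a lower number, and that gap is beyond the usual scatter. Going by the values given here, no pair of measured compounds differs in one place only, so no single-change step is available for reference.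

Compound 4 `O=C(Nc1nc(-c2cccc(NC(=O)C3CCCCC3)c2)cs1)c1ccc([N+](=O)[O-])o1` is the next member awaiting this assay. Relative to compound 1, the change is (cyclohexylcarbonyl)amino in place of bromo on an aromatic carbon, on an aromatic carbon of a six-membered aromatic ring of carbon only. Nothing in the measured set isolates this kind of change, so the expectation rests on the numbers of compound 1 and compound 2 alone: both lie at high concentrations, and the change is expected to leave compound 4 in the same region, with any step from compound 1 expected to stay within, or only modestly beyond, the scatter, most likely toward a somewhat lower number. The expected step is a 1.4-fold lower number from compound 1 to compound 4 (0.15 log units; within the scatter). Compound 4 is estimated at 50000 nM, with a range of 20000 nM to 120000 nM.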

Compound 4, half-maximal inhibitory concentration: 21900 nM
Compound 4: middle estimate off by 2.3-fold (0.36 log units), on the high side; the range from low to high includes it.
By their numbers in this assay, from the lowest: compounds 4 and 2 (each within the scatter of the next); then compound 1.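

Going by these compounds alone, replacing bromo with (cyclohexylcarbonyl)amino on this aromatic carbon, meta to a large group, gives a 3.2-fold lower number from compound 1 to compound 4 (0.51 log units; beyond the scatter) in this assay; this is the only single-change step in hand, and it shows that the read-out responds to the substituent at this position. The direction is toward stronger inhibition, yet compound 4 at 21900 nM still lies at a high concentration, so a much larger group at this position, bringing a six-membered non-aromatic ring of carbon only, a hydrogen-bond donor and a hydrogen-bond acceptor, produces a modest step rather than a large one. These features enter together, so this pair cannot assign the step to any one of them, and no available evidence bears on the cause of the result.

Open, going by these compounds, is whether the step follows the cyclohexyl ring or the carbonyl and amino link, which a plain amine or an acetylamino group on the same carbon would help to separate. Also open, on these data alone, is how a carboxylic acid or a longer alkyl chain at this position would read in this assay, and whether the step holds on other substituted rings of the series.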